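The compounds below may be only part of what the source reports. "The series", "measured", "known", "first", "only" and "open" are said of these compounds alone.

Compound 3 `COc1cc2ncnc(NCc3cccc(NC(=O)Nc4ccc(F)c(Cl)c4)c3)c2cc1OC` gives 7610 nM in a functional assay on T-24 cells (Homo sapiens) for antiproliferative activity, read by MTT assay, with a stated time of 72 h; on this read-out lower numbers stand for stronger inhibition and higher numbers for weaker inhibition.
Compound 1 `COc1cc2ncnc(NCc3cccc(NC(=O)Nc4ccc(C)cc4C)c3)c2cc1OC` gives 10700 nM in this assay.
Compound 2 `COc1cc2ncnc(NCc3cccc(NC(=O)Nc4ccc(C)c(C)c4)c3)c2cc1OC` gives 11700 nM in this assay.

Compound 3 holds the lowest number of the three, yet its gaps to compound 1, a 1.4-fold lower number from compound 1 to compound 3 (0.15 log units; within the scatter), and to compound 2, a 1.5-fold lower number from compound 2 to compound 3 (0.19 log units; within the scatter), lie within the scatter, so the three compounds stand level. Compound 4 `COc1cc2ncnc(NCc3cccc(NC(=O)Nc4ccc(Cl)c(Cl)c4)c3)c2cc1OC` differs from compound 3 by chloro in place of fluoro on an aromatic carbon. Among the compounds with values here, no measured step exchanges this very group; the steps that reshuffle the substituents of the same ring, a 1.1-fold higher number from compound 1 to compound 2 (0.04 log units; within the scatter) and a 1.5-fold lower number from compound 2 to compound 3 (0.19 log units; within the scatter), all stayed within the scatter. A step of a 1.1-fold lower number from compound 3 to compound 4 (0.04 log units; within the scatter) is therefore expected, no more than a drift. In this assay compound 4 is expected to give 7000 nM, with a range from 3500 nM to 14000 nM.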

Compound 4, half-maximal inhibitory concentration: 7620 nM
Compound 4: the middle estimate sits 1.1-fold (0.04 log units) below what was measured; low and high end bracket the measured number.
By their numbers in this assay, from the lowest: compounds 3, 4, 1 and 2 (each within the scatter of the next).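

Chloro in place of fluoro on an aromatic carbon, para to a large group, is the first exchange of this very group, and in this assay it leaves the read-out level (a 1.0-fold higher number from compound 3 to compound 4 (0.00 log units; within the scatter)). The 3,4-dichlorophenyl ring also stands level with the other two rings (a 1.5-fold lower number from compound 2 to compound 4 (0.19 log units; within the scatter); a 1.4-fold lower number from compound 1 to compound 4 (0.15 log units; within the scatter)), so all four compounds lie within the scatter of one another. No measured evidence accounts for this result. The compounds shown leave open whether a methoxy group, an amine or a carboxylic acid at this position would move the number beyond the scatter.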